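Phenyl in place of isobutoxy on a saturated ring carbon

The source may report more compounds than this note shows. Statements on the series, on what has been measured and on what is new or still open speak of the compounds shown alone.

Among the compounds with values here, in a functional assay on A549 cells (Homo sapiens) for inhibition, read by sulforhodamine B assay, with a stated time of 48 h (on this read-out lower numbers stand for stronger inhibition and higher numbers for weaker inhibition), compound 2 (`Cc1ccc2occ([C@@H]3C[C@H](OCC(C)C)ON3c3ccccc3)c(=O)c2c1`) gives 17100 nM, the only true number so far. Compound 1 (`O=c1c([C@@H]2C[C@H](c3ccccc3)ON2c2ccccc2)coc2ccccc12`), which also bears a phenyl group, reaches only a limit of the assay, > 60000 nM. Compound 3 (`Cc1ccc2occ([C@@H]3C[C@H](c4ccccc4)ON3c3ccccc3)c(=O)c2c1`) departs from compound 2 by phenyl in place of isobutoxy on a saturated ring carbon, with phenyl in place of isobutoxy on a saturated ring carbon. Resting on the limit of compound 1, > 60000 nM, weaker inhibition is expected. The expected change in this assay is a modest weakening beyond the scatter, a 2.3-fold higher number from compound 2 to compound 3 (0.37 log units; beyond the scatter). For compound 3 the estimate is 40000 nM, with an expected range of 15000 nM to 100000 nM.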

Compound 3, half-maximal inhibitory concentration: 49000 nM
Estimate against measurement, compound 3: 1.2-fold (0.09 log units) below; the measured number falls inside the stated range.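

Phenyl in place of isobutoxy on a saturated ring carbon, next to the ring oxygen, now has a measured size in this assay: a 2.9-fold higher number from compound 2 to compound 3 (0.46 log units; beyond the scatter) with both values true numbers, so phenyl gives weaker inhibition than isobutoxy here. Methyl in place of hydrogen on an aromatic carbon gives an at least 1.2-fold lower number from compound 1 to compound 3 (0.08 log units; that floor lies within the scatter) and that floor resolves no effect of the methyl. Compound 1 stands at a limit of the assay, so this second step has no upper bound: the limit of > 60000 nM in this assay, at which 1 of the 3 values shown sits.

On these data alone, whether an amine or a longer alkoxy chain on this ring carbon would give stronger inhibition than isobutoxy remains open.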